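The source may report more compounds than this note shows. Statements on the series, on what has been measured and on what is new or still open speak of the compounds shown alone.

Three compounds of the series have been run in a functional assay on A549 cells (Homo sapiens) for inhibition, read by MTT assay, with a stated time of 72 h; on this read-out lower numbers stand for stronger inhibition and higher numbers for weaker inhibition. Compound 1 `O=C(NNC(=O)C1CC1c1ccc(OC(F)(F)F)cc1)c1ccncc1` gives 56000 nM; compound 2 `CCOc1ccc(C2CC2C(=O)NNC(=O)c2ccncc2)cc1` gives 43000 nM; compound 3 `O=C(NNc1nncc2ccccc12)C1CC1c1ccc(OC(F)(F)F)cc1` gives 87000 nM. Compound 3 stands highest of the three numbers, within the scatter of compound 1 and beyond it only against compound 2. Among the compounds with values here, the one step between measured compounds that differ in a single place, a 1.3-fold lower number from compound 1 to compound 2 (0.11 log units; within the scatter), exchanges ethyl for trifluoromethyl on the oxygen on the aromatic ring and stays within the scatter.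

Compound 4 `CC(C)=CCOc1ccc(C2CC2C(=O)NNc2nncc3ccccc23)cc1` is not yet measured. It differs from compound 3 by 3-methylbut-2-en-1-yl in place of trifluoromethyl on an oxygen on an aromatic ring. The step from compound 1 to compound 2 bears on it, since that step also replaces trifluoromethyl on the same oxygen by a saturated chain, and the number moved little. Within the data shown here, no measured pair exchanges trifluoromethyl for 3-methylbut-2-en-1-yl, so the longer chain with its double bond has no precedent. The expected step in this assay is therefore small, a 1.5-fold lower number from compound 3 to compound 4 (0.16 log units; within the scatter), towards a lower number or none beyond the scatter. Compound 4 is estimated at 60000 nM, with a range from 25000 nM to 150000 nM.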

Compound 4, half-maximal inhibitory concentration: 82000 nM
Compound 4: the middle estimate sits 1.4-fold (0.14 log units) below what was measured; the range from low to high includes it.
By their numbers in this assay, from the lowest: compounds 2, 1, 4 and 3 (each within the scatter of the next, the first and the last beyond it).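

In this assay the step of a 1.1-fold lower number from compound 3 to compound 4 (0.03 log units; within the scatter) shows that the oxygen on the aromatic ring tolerates 3-methylbut-2-en-1-yl in place of trifluoromethyl, so a chain with a double bond outside the aromatic rings leaves the number within the scatter. With a 1.3-fold lower number from compound 1 to compound 2 (0.11 log units; within the scatter) as the second exchange at this oxygen, the same outcome now appears on two different cores, and neither of these two pairs goes against it. No measured evidence is available to explain why these exchanges at this position leave the number within the scatter.

Whether a group of another kind on this oxygen, such as an amine or a carboxylic acid at the end of a longer chain, would carry the number beyond the scatter stays open, since only trifluoromethyl, ethyl and 3-methylbut-2-en-1-yl are shown here. Also open, on these data alone, is whether single changes elsewhere on the core would move the number further than the exchanges at this oxygen have done.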